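From hydroxy to methoxy on compound 1

This account rests on a few compounds, and the source may have more. Where it says the series, first, only, none or still open, it means among the compounds named here.

Measured so far:
- compound 1 `O=C(NCCCNc1cc(-c2cn(-c3ccccc3)nc2-c2cccc(O)c2)ccn1)Nc1ccc(F)cc1`: 1250 nM
- compound 2 `O=C(NCCCNc1cc(-c2cn(-c3ccccc3)nc2-c2cccc(O)c2)ccn1)Nc1cccc(C(F)(F)F)c1`: 1670 nM

Among the compounds with values here, in a functional assay on MOLT-4 cells (Homo sapiens) for antiproliferative activity, read by sulforhodamine B assay, with a stated time of 48 h (on this read-out lower numbers stand for stronger inhibition and higher numbers for weaker inhibition), compound 1 stands at 1250 nM, and its only measured neighbour lies within the scatter of it: a 1.3-fold higher number from compound 1 to compound 2 (0.13 log units; within the scatter). The two values therefore mark a single level. Compound 3 `COc1cccc(-c2nn(-c3ccccc3)cc2-c2ccnc(NCCCNC(=O)Nc3ccc(F)cc3)c2)c1` keeps the core of compound 1 and differs at one place: methyl in place of hydrogen on an oxygen on an aromatic ring. This is methyl in place of hydrogen on an oxygen on an aromatic ring, or 3-hydroxyphenyl to 3-methoxyphenyl. Within the data shown here, no measured compound tests this oxygen, and the one measured step, made elsewhere in the molecule, offers only a general sense of scale. With a 1.3-fold higher number from compound 1 to compound 2 (0.13 log units; within the scatter) as that scale, a modest step is expected, with a tentative lean towards a higher number. The estimated change is a 1.6-fold higher number from compound 1 to compound 3 (0.20 log units; within the scatter). For compound 3 the expected value is 2000 nM. The estimated range runs from 700 nM to 6000 nM.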

Compound 3, half-maximal inhibitory concentration: 3940 nM
For compound 3 the middle estimate is 2.0-fold (0.29 log units) below the measured one, and the stated range covers the measured number.
By their numbers in this assay, from the lowest: compounds 1 and 2 (each within the scatter of the next); then compound 3.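

In this assay, methyl in place of hydrogen on an oxygen on an aromatic ring gives a 3.2-fold higher number from compound 1 to compound 3 (0.50 log units; beyond the scatter) and so moves the number beyond the scatter, whereas the earlier change on an amide-type nitrogen gave a 1.3-fold higher number from compound 1 to compound 2 (0.13 log units; within the scatter) and stayed within it. Within the data shown here, this oxygen is therefore the first place in these compounds where a one-place change separates two levels, with the free hydroxy on the lower number and the methoxy on the higher one. Nothing available explains the rise.

The compounds shown leave open whether the step follows the loss of the hydrogen or the arrival of the methyl, and how an amine or an ethoxy group at this place would read. They also leave open whether the same change on compound 2 would give a step of similar size.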